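The compounds below may be only part of what the source reports. "The series", "measured", "known", "first", "only" and "open" are said of these compounds alone.

Among the compounds with values here, in a functional assay on HCT-116 cells (Homo sapiens) for antiproliferative activity, read by MTT assay, with a stated time of 72 h (a higher number here means a weaker inhibitor, a lower number a stronger inhibitor), three compounds have numbers so far. Compound 1 `NC1=NC2(CCSCC2)N(OCCCOc2ccc(Br)cc2)C(N)=N1` gives 20 nM, the lowest of the three. Compound 2 `NC1=NC2(CCOCC2)N(OCCCOc2ccccc2Cl)C(N)=N1` gives 70 nM, and compound 3 `Cc1cc(C)cc(OCCCON2C(N)=NC(N)=NC23CCOCC3)c1` gives 190 nM. Compound 4 `NC1=NC2(CCSCC2)N(OCCCOc2cccc(Br)c2)C(N)=N1` has not yet been measured. It keeps the core of compound 1 and carries 3-bromophenyl in place of 4-bromophenyl on an oxygen on a saturated carbon. Within the data shown here, no measured pair moves a bromine in this way. The nearest evidence is a 2.7-fold higher number from compound 2 to compound 3 (0.43 log units; beyond the scatter), where 3,5-dimethylphenyl replaces 2-chlorophenyl at the same place, on a core that differs from that of compound 1. Among the measured compounds shown here, that modest step involves different groups, so it shows only that a change at this place can move the number beyond the scatter. Since compound 1 already stands lowest at 20 nM, a small rise is the likelier outcome, although a result within the scatter would be unsurprising. The expected change is a 1.8-fold higher number from compound 1 to compound 4 (0.24 log units; within the scatter). Compound 4 is estimated at 35 nM, with an expected range of 12 nM to 100 nM.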

Compound 4, half-maximal inhibitory concentration: 1 nM
Beside the measured number, compound 4's estimate is 35-fold (1.54 log units) above it; the whole stated range lies above it.
By their numbers in this assay, from the lowest: compound 4; then compound 1; then compound 2; then compound 3.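

In this assay the change from 4-bromophenyl to 3-bromophenyl gives a 20-fold lower number from compound 1 to compound 4 (1.30 log units; beyond the scatter) on an unchanged core, with the same atoms in the leaving and entering groups. The earlier compounds shown here offered only a 2.7-fold higher number from compound 2 to compound 3 (0.43 log units; beyond the scatter) for a swap of different groups at this place, so this result shows something new: the way the bromine is joined to the ring can by itself produce a large step here. No measured property of these groups is available to account for the step.

The compounds shown leave open whether 3-bromophenyl would give a step of similar size on the core of compound 2. They also leave open whether a nitrile or a methoxy group in place of the bromine of 3-bromophenyl would keep the number as low as that of compound 4.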